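The compounds below may be only part of what the source reports. "The series", "measured", "known", "first", "only" and "open" are said of these compounds alone.

Of the compounds shown here, three have so far been measured in a functional assay on the whole organism (B cells) with Mus musculus as the target; a lower number here means a smaller maximal response, a higher number a larger maximal response. Compound 1 `C=CCn1c(=O)n(C2C=CC(CO)O2)c2nc(N)nc(O)c21` gives 45%. Compound 2 `Nc1nc(O)c2c(n1)n(C1OC(CO)[C@@H](O)[C@H]1O)c(=O)n2CC(O)CSc1ccccc1` gives 12%, and compound 3 `C=CCn1c(=S)n(C2OC(CO)[C@@H](O)C(O)[C@H]2O)c2nc(N)nc(O)c21` gives 5%. Among these three numbers compound 2 stands second highest; its number and that of compound 3 lie within the usual scatter of each other, while compound 1 lies beyond the scatter above compound 2.

Compound 4 `CCCCCCCCCCn1c(=O)n(C2OC(CO)[C@@H](O)[C@H]2O)c2nc(N)nc(O)c21` has not yet been measured. It differs from compound 2 in one place: nonyl in place of 1-hydroxy-2-(phenylsulfanyl)ethyl on a saturated chain carbon bound to an aromatic nitrogen. Among the measured compounds shown here, no measured pair differs in a single place, so no comparable step has been seen, and the expectation can rest only on the three measured numbers and on the change itself.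

The step from compound 2 to compound 4 is expected to be small and upward, a number 8 percentage points higher from compound 2 to compound 4 (within the scatter), close to the edge of the scatter, since the measured numbers all stay modest. For compound 4 in this assay the expected value is 20%, with a range from 4% to 45%.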

Compound 4, largest response reached (reported as maximal response), in percent of the reference or control that the assay uses: 0%
Estimate against measurement, compound 4: 20 percentage points above, outside the stated range (below it).
By their numbers in this assay, from the lowest: compounds 4, 3 and 2 (each within the scatter of the next, the first and the last beyond it); then compound 1.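

Among the compounds shown here, at this position, a saturated chain carbon bound to an aromatic nitrogen, the side chain can now be compared directly for the first time in this assay, and the response does depend on what the chain carries (a number 12 percentage points lower from compound 2 to compound 4 (beyond the scatter)). With nonyl, a plain carbon chain without ring, oxygen or sulfur, compound 4 gives 0% and so keeps none of the modest response seen with 1-hydroxy-2-(phenylsulfanyl)ethyl. Nothing available explains why the response falls.

As far as these compounds go, this one change removes the aromatic ring, the hydroxyl and the sulfur together, so it remains open which of them matters, if any does. Also open, from the compounds shown here alone, is how a shorter chain such as propyl, or a chain ending in an amine or a carboxylic acid, would behave at this position.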